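Swapping the Aryl Substituent on a Shared Core

The compounds below may be only part of what the source reports. "The series", "measured", "known", "first", "only" and "open" are said of these compounds alone.

Of the compounds shown here, three built on one shared core have been tested in a functional assay on KBVIN cells (Homo sapiens) for antiproliferative activity, read by sulforhodamine B assay, with a stated time of 3 days; on this read-out higher numbers stand for an effect only at larger amounts of compound and lower numbers for an effect already at smaller amounts. Compound 1 `CCC1=C(O)c2c(oc(-c3ccc(CC(C)C)cc3)cc2=O)C(CC)(CC)C1=O` gives 17.4 uM, compound 2 `CCC1=C(O)c2c(oc(-c3ccc(C(F)(F)F)cc3)cc2=O)C(CC)(CC)C1=O` gives 10.4 uM, and compound 3 `CCC1=C(O)c2c(oc(-c3ccc(F)cc3)cc2=O)C(CC)(CC)C1=O` gives 1.85 uM, the lowest number of the three. The steps of a 9.4-fold lower number from compound 1 to compound 3 (0.97 log units; beyond the scatter) and a 5.6-fold lower number from compound 2 to compound 3 (0.75 log units; beyond the scatter) both lie beyond the scatter, whereas a 1.7-fold lower number from compound 1 to compound 2 (0.22 log units; within the scatter) stays within it.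

Compound 4 `CCC1=C(O)c2c(oc(-c3ccc(C)c(Cl)c3)cc2=O)C(CC)(CC)C1=O` has not yet been measured. It differs from compound 3 in a single place: 3-chloro-4-methylphenyl in place of 4-fluorophenyl on an aromatic carbon. The measured steps that bear on this change are the two that exchanged the group on the same phenyl ring, and in both of them moving away from fluoro toward isobutyl or trifluoromethyl went with a higher number. A rise in the number is therefore expected for compound 4, with the step of a 3.2-fold higher number from compound 3 to compound 4 (0.51 log units; beyond the scatter) estimated to be modest but beyond the scatter. Compound 4 is expected to give 6 uM, with a likely range from 2 uM to 18 uM.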

Compound 4, concentration for half-maximal effect: 2.15 uM
Beside the measured number, compound 4's estimate is 2.8-fold (0.45 log units) above it, within the range that was stated.
By their numbers in this assay, from the lowest: compounds 3 and 4 (each within the scatter of the next); then compounds 2 and 1 (each within the scatter of the next).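

The step of a 1.2-fold higher number from compound 3 to compound 4 (0.07 log units; within the scatter) shows that 4-fluorophenyl is not alone in giving a low number at this position: 3-chloro-4-methylphenyl, with two substituents on the phenyl ring instead of one, gives a number that cannot be told apart from it. Within the data shown here, in the earlier compounds, each exchange of the fluoro group, for isobutyl or for trifluoromethyl, went with a higher number beyond the scatter, and compound 4 goes against that pattern. No measurement is available that would explain this result.

The compounds shown leave open what the chloro and methyl groups each contribute, as neither appears alone on the phenyl ring. Going by these compounds, how an amine or a carboxylic acid on that ring would behave also remains open.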